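The source may report more compounds than this note shows. Statements on the series, on what has been measured and on what is new or still open speak of the compounds shown alone.

Working notes on the series, read in a functional assay on HCT-116 cells (Homo sapiens) for inhibition, read by MTT assay, with a stated time of 48 h; a lower number here means a stronger inhibitor, a higher number a weaker inhibitor. Compound 1 (`C/C=C/C(=O)N(Cc1ccc(OC)c([N+](=O)[O-])c1)c1cc(OC)c(OC)c(OC)c1`) gives 670 nM, compound 2 (`COc1ccc(CNc2cc(OC)c(OC)c(OC)c2)cc1[N+](=O)[O-]`) gives 18200 nM, and compound 3 (`CCCCC(=O)N(Cc1ccc(OC)c(O)c1)c1cc(OC)c(OC)c(OC)c1`) gives 170 nM. The number for compound 3 is the lowest of the three, and its gaps to the other two lie beyond the scatter.

Compound 4 (`COc1ccc(CN(C(=O)C=C(C)C)c2cc(OC)c(OC)c(OC)c2)cc1O`) is not yet measured and departs from compound 3 in one place: 2-methylprop-1-en-1-yl in place of butyl on a carbonyl carbon. This puts 2-methylprop-1-en-1-yl in place of butyl on a carbonyl carbon.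

Among the compounds with values here, the only measured single-place step is a 27-fold higher number from compound 1 to compound 2 (1.43 log units; beyond the scatter), a large change in which hydrogen replaces (prop-1-en-1-yl)carbonyl on a nitrogen. Compound 4 keeps its carbonyl, so that step sets no size for the present change and only shows that this part of the structure can matter. Compounds 1 and 3 differ in more than one place, so their gap cannot be assigned to the chain on the carbonyl. Within the data shown here, no measured step isolates a swap of butyl for 2-methylprop-1-en-1-yl, and no step beyond the scatter is expected in this assay, with a slight upward drift at most.

The expected change is a 1.3-fold higher number from compound 3 to compound 4 (0.11 log units; within the scatter). For compound 4 the estimated value is 220 nM, with an expected range from 70 nM to 700 nM.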

Compound 4, half-maximal inhibitory concentration: 290 nM
Beside the measured number, compound 4's estimate is 1.3-fold (0.12 log units) below it; low and high end bracket the measured number.
By their numbers in this assay, from the lowest: compounds 3 and 4 (each within the scatter of the next); then compound 1; then compound 2.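

In this assay, within the data shown here, the swap of butyl for 2-methylprop-1-en-1-yl on a carbonyl carbon gives a 1.7-fold higher number from compound 3 to compound 4 (0.23 log units; within the scatter), the first measured step that changes this chain while the carbonyl stays in place. The earlier 27-fold higher number from compound 1 to compound 2 (1.43 log units; beyond the scatter) came with the loss of the whole (prop-1-en-1-yl)carbonyl, whereas this step shows that, with the carbonyl kept, a saturated butyl and a 2-methylprop-1-en-1-yl carrying one double bond can be exchanged without a change beyond the scatter. No measurement at hand bears on why these two chains read alike, so the result stays an observation without an explanation.

The compounds shown leave open whether this position accepts chains of other kinds on the carbonyl carbon as readily, such as a longer chain, a phenyl ring, or a chain ending in an amine or a carboxylic acid. They also leave open whether the same swap reads alike when the hydroxy group of compound 3 and compound 4 is replaced by the nitro group carried by compound 1.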